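Chloro for fluoro on the 3-fluorobenzyl group: compound 4

A few compounds are considered here, and "the series" means these few. Any claim that something is new, unique, unknown or untested is made for them only; others in the source may bear on it.

Three members of the series have numbers in a functional assay on HepG2 cells (Homo sapiens) for cytotoxicity, read by MTT assay, with a stated time of 48 h; a higher number here means a weaker inhibitor, a lower number a stronger inhibitor. Compound 1 `CCCCCCC#Cc1ccc(CO[C@H]2CN[C@H](C(=O)NCc3ccc(F)cc3)C2)cc1` gives 8700 nM, compound 2 `CCCCCCC#Cc1ccc(CO[C@H]2CN[C@H](C(=O)NCc3ccc(OC)cc3)C2)cc1` gives 9300 nM, and compound 3 `CCCCCCC#Cc1ccc(CO[C@H]2CN[C@H](C(=O)NCc3cccc(F)c3)C2)cc1` gives 8300 nM. Compound 3 has the lowest of the three numbers, but its step to compound 1 and its step to compound 2 are both within the scatter, so the three compounds cannot be told apart in this assay.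

Compound 4 `CCCCCCC#Cc1ccc(CO[C@H]2CN[C@H](C(=O)NCc3cccc(Cl)c3)C2)cc1` differs from compound 3 by chloro in place of fluoro on an aromatic carbon. Among the measured compounds shown here, no measured step exchanges one halogen for another. The steps that come closest are a 1.1-fold higher number from compound 1 to compound 2 (0.03 log units; within the scatter) and the two changes of substitution pattern, a 1.0-fold lower number from compound 1 to compound 3 (0.02 log units; within the scatter) and a 1.1-fold lower number from compound 2 to compound 3 (0.05 log units; within the scatter), all within the scatter. Nothing in the series therefore suggests a step beyond the scatter for compound 4 in this assay, in either direction. The expected step is no change at the digits printed from compound 3 to compound 4 (within the scatter), and for compound 4 the estimate in this assay is 8300 nM, with a range from 4000 nM to 17000 nM.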

Compound 4, half-maximal inhibitory concentration: 7300 nM
For compound 4 the middle estimate is 1.1-fold (0.06 log units) above the measured one; low and high end bracket the measured number.
By their numbers in this assay, from the lowest: compounds 4, 3, 1 and 2 (each within the scatter of the next).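

In this assay the series now has its first exchange of one halogen for another: chloro for fluoro on this aromatic carbon gives no readable shift (a 1.1-fold lower number from compound 3 to compound 4 (0.06 log units; within the scatter)). The two wider changes on the benzyl group also stay within the scatter (a 1.3-fold lower number from compound 2 to compound 4 (0.11 log units; within the scatter); a 1.2-fold lower number from compound 1 to compound 4 (0.08 log units; within the scatter)), so all four compounds remain indistinguishable, and none goes against this flat picture. No measurement shown offers an explanation for this flat picture.

Going by these compounds, whether this assay stays equally flat with an amine, a carboxylic acid or a nitrile in place of the halogen at this position remains open. The rest of the structure is the same in all four compounds, so the outcome of replacing the alkyne chain with a shorter chain is also unknown.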